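From compound 3 to compound 4: cyclopropyl enters

This account rests on a few compounds, and the source may have more. Where it says the series, first, only, none or still open, it means among the compounds named here.

Compound 1 `COc1ccc(-c2cn(CC3=C(Cl)c4ccc(-c5cccs5)nc4CC3)nn2)cc1` gives > 300 ug/mL (a limit)
Compound 2 `Fc1ccc(-c2cn(CC3=C(Cl)c4ccc(-c5cccs5)nc4CC3)nn2)cc1` gives 100 ug/mL
Compound 3 `FC(F)(F)c1ccccc1-c1cn(CC2=C(Cl)c3ccc(-c4cccs4)nc3CC2)nn1` gives > 300 ug/mL (a limit)

These three compounds share a core and differ only in one substituent. In an ADME assay on MDCK cells (Canis lupus familiaris) for cytotoxicity, read by MTT assay, with a stated time of 48 h (a higher number here means that more compound is tolerated, a lower number that less compound is tolerated), compound 3 gives > 300 ug/mL as its result, which is a limit. Compound 3 thus stands at the limit of > 300 ug/mL in this assay, at which 2 of the 3 values shown sit, and offers no exact starting point.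

The next compound, compound 4 `ClC1=C(Cn2cc(C3CC3)nn2)CCc2nc(-c3cccs3)ccc21`, carries cyclopropyl in place of 2-(trifluoromethyl)phenyl on an aromatic carbon.

Two measured steps change this substituent (an at least 3.0-fold lower number from compound 1 to compound 2 (0.47 log units; beyond the scatter); an at least 3.0-fold higher number from compound 2 to compound 3 (0.47 log units; beyond the scatter)), and both are at least modest, so changes here can move the number beyond the scatter. The remaining step (a step that the two limits leave unreadable from compound 1 to compound 3) cannot be read. None of the three brings in cyclopropyl, so the direction of the new step is only a tentative guess.

Compound 2 at 100 ug/mL is the only one of the three with an exact number, and it suggests that lower values can occur among these compounds. A modest fall in this assay is therefore expected, and the estimated step is an at least 1.5-fold lower number from compound 3 to compound 4 (0.17 log units; that floor lies within the scatter) with wide uncertainty. For compound 4 the estimated value is 200 ug/mL with an expected range from 80 ug/mL to 450 ug/mL in this measurement.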

Compound 4, half-maximal cytotoxic concentration: > 300 ug/mL
Compound 4: only a limit was reported; the forecaster's own chance of this, stated with the estimate: 40%; middle value at least 1.5-fold (0.17 log units) away from the limit.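

In this assay compound 4 gives > 300 ug/mL, which is a limit. The earlier compounds shown here all carried a substituted phenyl ring on this carbon of the five-membered aromatic ring, and this result shows that a much smaller group, cyclopropyl with its 3 heavy atoms and no aromatic ring, can stand there with an at least 3.0-fold higher number from compound 2 to compound 4 (0.47 log units; beyond the scatter), while the steps from compound 1 and compound 3 cannot be read, as both ends of each are limits. Compound 2 is now the one compound that goes against the pattern in this small set, where the results gather at a single limit: the limit of > 300 ug/mL in this assay, at which 3 of the 4 values shown sit.

Going by these compounds alone, with only one exact number among the four compounds, the set leaves open how far the result can really move at this position and how much of the difference between the groups stays hidden behind the limit. It also leaves open whether an amine, a carboxylic acid or a longer chain on this carbon would stay at the limit, like compound 4, or give an exact and lower number, like compound 2.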